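This account rests on a few compounds, and the source may have more. Where it says the series, first, only, none or still open, it means among the compounds named here.

Working notes on the thiophene-urea series.

Compound 1 `CCN1CCc2c(sc(NC(=O)Nc3ccc(Cl)cc3)c2C(N)=O)C1` is the reference; in a functional assay (strain AB) with Danio rerio as the target, read by microscopy, with a stated time of 1 h (on this read-out higher numbers stand for an effect only at larger amounts of compound and lower numbers for an effect already at smaller amounts), compound 1 gives 3120 nM. Compound 3 `CCCN1CCc2c(sc(NC(=O)Nc3ccc(Cl)cc3)c2C(N)=O)C1` differs from it by methyl in place of hydrogen on a saturated chain carbon, two bonds along the chain from an amine nitrogen in a ring, and in this assay compound 3 gives 3500 nM; the step of a 1.1-fold higher number from compound 1 to compound 3 (0.05 log units; within the scatter) shows the two cores as equivalent within the noise. Compound 2 `CC(C)(C)OC(=O)CCCN1CCc2c(sc(NC(=O)Nc3ccc(Cl)cc3)c2C(N)=O)C1` carries (tert-butoxycarbonyl)methyl in place of hydrogen on a saturated chain carbon, two bonds along the chain from an amine nitrogen in a ring on the core of compound 1, and in this assay compound 2 gives 560 nM, a step of a 5.6-fold lower number from compound 1 to compound 2 (0.75 log units; beyond the scatter), the only move beyond the scatter among the three measured compounds.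

Compound 4 `CC(C)(C)OC(=O)CCCCN1CCc2c(sc(NC(=O)Nc3ccc(Cl)cc3)c2C(N)=O)C1` is not yet measured. It carries (tert-butoxycarbonyl)methyl in place of hydrogen on a saturated chain carbon, three bonds along the chain from an amine nitrogen in a ring on the core of compound 3. Among the compounds with values here, this is the same kind of change as the one from compound 1 to compound 2, but not the same: the group sits three bonds along the chain from the amine nitrogen in the ring instead of two. Within the data shown here, with only one measured instance of this change, the expected step from compound 3 to compound 4 is put at a 5.4-fold lower number from compound 3 to compound 4 (0.73 log units; beyond the scatter), set beside a 5.6-fold lower number from compound 1 to compound 2 (0.75 log units; beyond the scatter) because the cores of compound 1 and compound 3 sit within the scatter of each other a 1.1-fold higher number from compound 1 to compound 3 (0.05 log units; within the scatter). Among the measured compounds shown here, compound 4 is thus estimated at 650 nM, with a range from 250 nM to 1800 nM reflecting the single precedent and the shifted place.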

Compound 4, half-maximal effective concentration: 710 nM
The estimate for compound 4 lay 1.1-fold (0.04 log units) below the measured number, within the range that was stated.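

In this assay, (tert-butoxycarbonyl)methyl in place of hydrogen again gives a step beyond the scatter (a 4.9-fold lower number from compound 3 to compound 4 (0.69 log units; beyond the scatter)), and the size of the step carries over from the core of compound 1 to the core of compound 3: the same change on two cores in this assay, a 5.6-fold lower number (0.75 log units; beyond the scatter) from compound 1 to compound 2 and a 4.9-fold lower number (0.69 log units; beyond the scatter) from compound 3 to compound 4, 1.1-fold (0.05 log units) apart, within the scatter of two such steps. The two ester-bearing compounds cannot be told apart (a 1.3-fold higher number from compound 2 to compound 4 (0.10 log units; within the scatter)), and the step from the shared reference remains beyond the scatter (a 4.4-fold lower number from compound 1 to compound 4 (0.64 log units; beyond the scatter)). Within the data shown here, this is only two instances of one change, on two cores that themselves sit within the scatter of each other, so it shows transfer between these closely matched cores and does not show that the change would carry to a more different core or give any reason for the step.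

On these data alone, whether the step depends on the tert-butoxycarbonyl group itself stays open, and a carboxylic acid or an amine in its place would test this. As far as these compounds go, how far the step persists on a longer chain also remains open.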